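The source may report more compounds than this note shows. Statements on the series, on what has been measured and on what is new or still open speak of the compounds shown alone.

Measured in a functional assay for inhibition of nuclear factor NF-kappa-B complex (Homo sapiens); on this read-out higher numbers stand for weaker inhibition and lower numbers for stronger inhibition:
compound 1 `CCCC(=O)C1=Cc2ccc(OC)cc2OC1c1cc(OC)c(OC)c(OC)c1` gives 11700 nM
compound 2 `CCOC(=O)C1=Cc2ccc(OC)cc2OC1c1cc(OC)c(OC)c(OC)c1` gives 25000 nM
compound 3 `COc1ccc2c(c1)OC(c1cc(OC)c(OC)c(OC)c1)C(C(=O)OC(C)(C)C)=C2` gives 14100 nM

Compound 1 holds the lowest number of the three; compound 3 sits nearest, within the scatter, and compound 2 furthest, beyond it. Compound 4 `CCCCNC(=O)C1=Cc2ccc(OC)cc2OC1c1cc(OC)c(OC)c(OC)c1` differs from compound 1 by butylamino in place of propyl on a carbonyl carbon. Two measured steps change the same carbonyl carbon away from propyl: a 2.1-fold higher number from compound 1 to compound 2 (0.33 log units; beyond the scatter) and a 1.2-fold higher number from compound 1 to compound 3 (0.08 log units; within the scatter). Both moved the number upward, one modestly and one within the scatter, and the step between them, a 1.8-fold lower number from compound 2 to compound 3 (0.25 log units; within the scatter), also stays within the scatter. The butylamino change is expected to behave similarly in this assay, a small rise or none beyond the scatter. For compound 4 the expected step is a 1.3-fold higher number from compound 1 to compound 4 (0.11 log units; within the scatter). Compound 4 is estimated at 15000 nM, between 7000 nM and 35000 nM.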

Compound 4, half-maximal inhibitory concentration: 25500 nM
The estimate for compound 4 lay 1.7-fold (0.23 log units) below the measured number; the range from low to high includes it.
By their numbers in this assay, from the lowest: compounds 1, 3, 2 and 4 (each within the scatter of the next, the first and the last beyond it).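

In this assay butylamino on this carbonyl carbon, the only replacement here that brings in nitrogen and a hydrogen-bond donor, gives a 2.2-fold higher number from compound 1 to compound 4 (0.34 log units; beyond the scatter) and so joins ethoxy in a step beyond the scatter. Against the oxygen-linked groups the steps are a 1.0-fold higher number from compound 2 to compound 4 (0.01 log units; within the scatter) and a 1.8-fold higher number from compound 3 to compound 4 (0.26 log units; within the scatter) and neither separates butylamino from them. Nothing measured here bears on the reason for these steps.

Open, as far as these compounds go, is whether methylamino, dimethylamino or a carboxylic acid at this carbonyl carbon would group with compound 1 or with compound 4. Among the compounds shown here, the effect of chain length on the nitrogen also remains open, with butylamino the only such group.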